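The compounds below may be only part of what the source reports. "The series", "measured", "known", "first", "only" and "open" are said of these compounds alone.

Compound 1 `CCN(CC)C(=O)N1CCN(/[N+]([O-])=N/Oc2cc(O/N=[N+](\[O-])N(C)C)c([N+](=O)[O-])cc2[N+](=O)[O-])CC1`: 4900 nM
Compound 2 `CN(C)/[N+]([O-])=N/Oc1cc(O/N=[N+](\[O-])N2CCN(c3ncccn3)CC2)c([N+](=O)[O-])cc1[N+](=O)[O-]`: 5000 nM

In a functional assay on HL-60 cells (Homo sapiens) for antiproliferative activity, read by MTT assay, with a stated time of 72 h (a higher number here means a weaker inhibitor of growth, a lower number a stronger inhibitor of growth), compound 1 gives 4900 nM, level within the scatter with compound 2 at 5000 nM. Compound 3 `CCN(CC)C(=O)N1CCN(/[N+]([O-])=N/Oc2cc(O/N=[N+](\[O-])N(CC)CC)c([N+](=O)[O-])cc2[N+](=O)[O-])CC1` carries diethylamino in place of dimethylamino on a double-bonded nitrogen, with diethylamino in place of dimethylamino on a double-bonded nitrogen. Among the compounds with values here, the only measured step, a 1.0-fold higher number from compound 1 to compound 2 (0.01 log units; within the scatter), is a change at another place, so no measurement tests this change directly. That step stayed within the scatter, and no shift beyond the scatter is expected in this assay. The expected change is a 1.1-fold lower number from compound 1 to compound 3 (0.04 log units; within the scatter). For compound 3 the estimated value is 4500 nM, with an expected range from 1700 nM to 11000 nM.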

Compound 3, concentration for total growth inhibition: > 10000 nM
Compound 3: only a limit was reported; the forecaster's own chance of this, stated with the estimate: 5%; at least 2.2-fold (0.34 log units) between middle value and limit.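

Within the data shown here, changing this position for the first time, diethylamino in place of dimethylamino on a double-bonded nitrogen gives an at least 2.0-fold higher number from compound 1 to compound 3 (0.30 log units; that floor lies within the scatter). In this assay compound 3 gives > 10000 nM, which is a limit and not a number. The earlier step, at another place, stayed within the scatter, whereas this change leaves only a floor, so it hints at a loss of growth inhibition without establishing one: the limit of > 10000 nM in this assay, at which 1 of the 3 values shown sits.

On these data alone, how far compound 3 truly lies from compound 1 stays open. So does whether dipropylamino or a pyrrolidine ring at this place would give a measurable value.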